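A few compounds are considered here, and "the series" means these few. Any claim that something is new, unique, unknown or untested is made for them only; others in the source may bear on it.

Measured compounds:
Compound 1 `O=C1CS/C(=N\c2csc(-c3ccccc3)c2)N1` — in a functional assay on MCF7 cells (Homo sapiens) for cytotoxicity, read by MTT assay, with a stated time of 72 h (on this read-out lower numbers stand for stronger inhibition and higher numbers for weaker inhibition), compound 1 gives > 50000 nM, which is a limit of the assay and not a number.
Compound 2 `O=C1CS/C(=N\c2csc(-c3ccc(Cl)cc3)c2)N1` — in this assay compound 2 gives > 50000 nM, again a limit.
Compound 3 `O=C1CS/C(=N\c2csc(-c3ccc(Cl)cc3)c2)N1c1ccc(Cl)cc1` — in this assay compound 3 gives > 50000 nM, again a limit.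

Among the measured compounds shown here, all three measured compounds sit at the limit of > 50000 nM in this assay, at which 3 of the 3 values shown sit, so no step among them can be read. The change from compound 2 to compound 1, (hydrogen in place of chloro on an aromatic carbon), gives a step that the two limits leave unreadable from compound 2 to compound 1. The core of compound 3 differs from that of compound 2 by 4-chlorophenyl in place of hydrogen on an amide-type nitrogen in a ring.

Compound 4 `O=C1CS/C(=N\c2csc(-c3ccc(Cl)cc3)c2)N1c1ccccc1` has not yet been measured. It differs from compound 3 by hydrogen in place of chloro on an aromatic carbon, the same change as that from compound 2 to compound 1, at the same place. Since that earlier change left both compounds at the limit, and compound 3 itself rests at > 50000 nM, compound 4 is expected to behave alike, with an estimated step that the limit leaves unreadable from compound 3 to compound 4. Compound 4 is therefore estimated at 60000 nM, most likely reported only as a limit, with an expected range from 20000 nM to 200000 nM.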

Compound 4, half-maximal inhibitory concentration: > 50000 nM
Compound 4 gave a limit, no number; the forecaster's own chance of this, stated with the estimate: 85%; the middle value is on the limit's open side.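

Compound 4 rests at the same limit as compound 1, compound 2 and compound 3, so neither its step from compound 3 nor its step from compound 2 can be read in this assay: the limit of > 50000 nM in this assay, at which 4 of the 4 values shown sit. The compounds shown leave open whether any change to the shared core would give a readable value, and so whether chloro, hydrogen, phenyl and 4-chlorophenyl differ at these places.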